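A Chloro-to-Fluoro Swap and Oral Bioavailability

This account rests on a few compounds, and the source may have more. Where it says the series, first, only, none or still open, it means among the compounds named here.

Within the data shown here, only two compounds have been measured so far in an ADME assay on the whole organism (Rattus norvegicus, strain Sprague-Dawley) for pharmacokinetics, using cassette dosing, at a dose of 1 mg/kg by the oral route; a lower number here means that a smaller share of the oral dose reaches the circulation, a higher number that a larger share of the oral dose reaches the circulation. Compound 1 (`O=C(c1cc(-c2ccc(=O)[nH]c2)on1)N1CCC(Cc2ccc(F)cc2)CC1`) gives 18.4%, and compound 2 (`O=C(Nc1ccc2[nH]c(=O)oc2c1)C(=O)N1CCN(c2ccc(Cl)cc2)CC1`) gives 17.8%. These two values lie within the usual scatter of each other, so neither compound can be ranked above the other, even though their structures differ widely. Compound 3 (`O=C(Nc1ccc2[nH]c(=O)oc2c1)C(=O)N1CCN(c2ccc(F)cc2)CC1`) has not yet been measured. It differs from compound 2 in one place: fluoro in place of chloro on an aromatic carbon. Put simply, 4-chlorophenyl becomes 4-fluorophenyl. Among the measured compounds shown here, no measured pair of compounds shows the effect of this swap, so no step beyond the scatter is expected, in either direction. The estimated change is a number 2.2 percentage points higher from compound 2 to compound 3 (within the scatter). Compound 3 is expected to give 20%, with an estimated range of 8% to 35%.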

Compound 3, oral bioavailability: 39.3%
Compound 3: the middle estimate sits 19.3 percentage points below what was measured; measured number above the stated range.
By their numbers in this assay, from the lowest: compounds 2 and 1 (each within the scatter of the next); then compound 3.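

In this assay the exchange of 4-chlorophenyl for 4-fluorophenyl gives a number 21.5 percentage points higher from compound 2 to compound 3 (beyond the scatter) and so shows that this place on the aromatic ring, para to a large group, can matter for how much of an oral dose reaches the circulation. Among these compounds, only one heavy atom changes while the rest of the molecule stays the same, so the whole step belongs to this single exchange. From the compounds shown here alone, no measurement here bears on how the exchange produces this step, and the reason remains unknown.

Still open, going by these compounds, is how other groups at this place would compare, such as a plain hydrogen, a methyl group or a methoxy group. Also open is whether the same exchange would give a similar step on another core, since this is the only pair shown that carries it.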